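Restoring a carbamoylamino group on compound 2

The source may hold more compounds than are shown below. What is called first, only, known or untested is meant among the compounds shown, and "the series" means these compounds.

Compound 1 `COc1cc(NC(C)CCCNC(=O)NNC(=O)Nc2ccc(Cl)cc2)c2ncccc2c1` - 180 nM
Compound 2 `COc1cc(NC(C)CCCNC(=O)Nc2ccc(F)cc2)c2ncccc2c1` - 26000 nM
Compound 3 `COc1cc(NC(C)CCCNC(=O)NNC(=O)Nc2cccc(F)c2)c2ncccc2c1` - not yet measured

Going by the values given here, in a functional assay on MCF7 cells (Homo sapiens) for inhibition, read by MTT assay, with a stated time of 72 h (on this read-out lower numbers stand for stronger inhibition and higher numbers for weaker inhibition), compound 2 gives 26000 nM, the higher of the two numbers so far and therefore the weaker inhibition. Compound 3 differs from it as follows: ((3-fluorophenyl)carbamoyl)amino in place of 4-fluorophenyl on an amide-type nitrogen. In words, ((3-fluorophenyl)carbamoyl)amino stands in place of 4-fluorophenyl on an amide-type nitrogen. Among the compounds with values here, one measured step bears on this change: a 140-fold higher number from compound 1 to compound 2 (2.16 log units; beyond the scatter). That step is large and beyond the scatter, and it went with the loss of ((4-chlorophenyl)carbamoyl)amino in favour of 4-fluorophenyl. The new change runs the opposite way, so a large fall in the number is expected, of broadly similar size. The match is not exact, since the entering group carries 3-fluorophenyl rather than 4-chlorophenyl, and no measurement shows what that difference does. The expected size of the change is an 87-fold lower number from compound 2 to compound 3 (1.94 log units; beyond the scatter), towards stronger inhibition. For compound 3 the estimated value is 300 nM, with an expected range from 80 nM to 1500 nM.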

Compound 3, half-maximal inhibitory concentration: 150 nM
Compound 3: the middle estimate sits 2.0-fold (0.30 log units) above what was measured, within the range that was stated.
By their numbers in this assay, from the lowest: compounds 3 and 1 (each within the scatter of the next); then compound 2.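

In this assay, placing ((3-fluorophenyl)carbamoyl)amino in place of 4-fluorophenyl on an amide-type nitrogen gives a 170-fold lower number from compound 2 to compound 3 (2.24 log units; beyond the scatter), so a direct step into the carbamoylamino series now stands beside the earlier step out of it, a 140-fold higher number from compound 1 to compound 2 (2.16 log units; beyond the scatter), and the two run in opposite directions. The new compound also separates the group's two parts to a limited degree: with 3-fluorophenyl in place of 4-chlorophenyl on an amide-type nitrogen, the result is a 1.2-fold lower number from compound 1 to compound 3 (0.08 log units; within the scatter), so this particular change of the aryl ring leaves the number within the scatter. Among the three compounds, the two carrying a carbamoylamino group both give low numbers and the one without it gives the high number, with none going against this pattern, though three compounds are a narrow basis for it.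

Going by these compounds, how much of the fall belongs to the carbamoylamino link itself remains open, as does whether a benzyl group or a carboxylic acid on the same amide-type nitrogen would keep the number low. Nothing measured here accounts for the size of the difference between the two kinds of compound.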